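The source may report more compounds than this note shows. Statements on the series, on what has been measured and on what is new or still open speak of the compounds shown alone.

In an ADME assay on the whole organism (Mus musculus, strain Swiss Webster) for pharmacokinetics, read by LC-MS, at a dose of 50 mg/kg by the oral route (a higher number here means more compound in the circulation at the dose given, a lower number less compound in the circulation), three compounds sharing one core have been measured. Compound 1 `O=C(Nc1ccc(F)c(-c2nc3ncc(-c4ccc(F)c(F)c4)cc3[nH]2)c1)N1CCCC1` gives 6670 nM, compound 2 `O=C(Nc1ccc(F)c(-c2nc3ncc(-c4cc(F)ccc4F)cc3[nH]2)c1)N1CCCC1` gives 2800 nM, and compound 3 `O=C(Nc1ccc(F)c(-c2nc3ncc(-c4ccc(F)cc4F)cc3[nH]2)c1)N1CCCC1` gives 9500 nM. The data do not separate compound 3 from compound 1, as the record shows a 1.4-fold higher number from compound 1 to compound 3 (0.15 log units; within the scatter). Compound 3 does stand clear of compound 2, with a 3.4-fold higher number from compound 2 to compound 3 (0.53 log units; beyond the scatter).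

Compound 4 `O=C(Nc1ccc(F)c(-c2nc3ncc(-c4cncc(F)c4)cc3[nH]2)c1)N1CCCC1` keeps the core but changes the aryl group: 5-fluoropyridin-3-yl in place of 2,4-difluorophenyl on an aromatic carbon, 5-fluoropyridin-3-yl in place of 2,4-difluorophenyl. The closest evidence comes from the difluorophenyl variants at this same place, where a 2.4-fold lower number from compound 1 to compound 2 (0.38 log units; beyond the scatter) shows that a change here can move the number modestly. Going by the values given here, none of the measured steps introduces a ring nitrogen, so they guide the size of this step only loosely. Compound 3, at 9500 nM, already sits in the upper part of the measured numbers, so a modest fall is expected in this assay. The expected change is a 2.1-fold lower number from compound 3 to compound 4 (0.32 log units; beyond the scatter). Compound 4 is estimated at 4500 nM, with an expected range of 1500 nM to 13000 nM.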

Compound 4, maximal plasma concentration: 1070 nM
For compound 4 the middle estimate is 4.2-fold (0.62 log units) above the measured one; the whole stated range lies above it.
By their numbers in this assay, from the lowest: compound 4; then compound 2; then compounds 1 and 3 (each within the scatter of the next).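

In this assay, bringing a ring nitrogen into the aryl group at this place comes with the largest step seen so far, an 8.9-fold lower number from compound 3 to compound 4 (0.95 log units; beyond the scatter), alongside a 6.2-fold lower number from compound 1 to compound 4 (0.79 log units; beyond the scatter) and a 2.6-fold lower number from compound 2 to compound 4 (0.42 log units; beyond the scatter). The 5-fluoropyridin-3-yl group thus sits below all three difluorophenyl groups, so this place can carry a lower number than moving fluorines around the phenyl ring had shown. No measurement offered here accounts for this fall.

The change puts a ring nitrogen in and leaves one fluorine fewer in a single move, and the compounds shown do not part the two. Also open, going by these compounds, is how an unsubstituted phenyl, a difluoropyridinyl group or a pyridine with its nitrogen elsewhere in the ring would read at this place.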